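The compounds below may be only part of what the source reports. "The series", "measured", "known", "first", "only" and "open" are said of these compounds alone.

Measured so far: compound 1 `CCCCCCCCOc1ccc(-c2c(C)[nH]c(=O)n2C)cc1` gives 30 mg/kg in a functional assay on the whole organism with Rattus norvegicus as the target; a lower number here means that less compound is needed, a higher number that more compound is needed for the effect; compound 2 `CCCCCCCCCCc1ccc(-c2c(C)[nH]c(=O)n2C)cc1` gives 0.3 mg/kg in this assay.

Compound 1 stands at the highest of the two numbers in this assay; compound 2 sits lower by a gap that lies beyond the usual scatter. Going by the values given here, no single-point step between these two measured compounds exists, so only their two values can be compared.

Compound 3 `CCCCCCCCCCCOc1ccc(-c2c(C)[nH]c(=O)n2C)cc1` arises from compound 1 by one change: propyl in place of hydrogen on a saturated chain carbon, eight bonds along the chain from an oxygen on an aromatic ring. Among the compounds with values here, no measured pair shows this change on its own, so the direction of the step rests on the lower dose of compound 2, which carries the longer chain. The account expects compound 3 to need a lower dose than compound 1, with a step of a 10-fold lower number from compound 1 to compound 3 (1.00 log units; beyond the scatter) in this assay, a change beyond the scatter. The dose for compound 3 in this assay is estimated at 3 mg/kg, within a range from 0.3 mg/kg to 30 mg/kg.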

Compound 3, minimum effective dose: 0.1 mg/kg
Compound 3: the middle estimate sits 30-fold (1.48 log units) above what was measured; measured number below the stated range.
By their numbers in this assay, from the lowest: compound 3; then compound 2; then compound 1.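

Putting propyl in place of hydrogen on a saturated chain carbon, eight bonds along the chain from an oxygen on an aromatic ring, gives a 300-fold lower number from compound 1 to compound 3 (2.48 log units; beyond the scatter) in this assay and counts as a large step. Going by these compounds alone, this is the first step that changes one place only, and it shows that extending the chain at this position, with the oxygen and the shared core left as they are, is enough to lower the dose needed. No evidence on hand bears on why the step is this large.

Only this one extension is shown, so it remains open whether a still longer chain would lower the dose further or raise it again. From the compounds shown here alone, it is equally open how an amine or a carboxylic acid at this position would fare.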